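A few compounds are considered here, and "the series" means these few. Any claim that something is new, unique, unknown or untested is made for them only; others in the source may bear on it.

Compound 1, `Oc1ccccc1-c1cc(-c2ccsc2)cc(-c2ccccc2O)n1`, in a functional assay on T47D cells (Homo sapiens) for cytotoxicity, read by CCK-8 assay (on this read-out higher numbers stand for weaker inhibition and lower numbers for stronger inhibition), reaches only a limit of the assay, > 50000 nM.
Compound 2, `Oc1ccccc1-c1cc(-c2ccoc2)cc(-c2ccccc2O)n1`, in this assay reaches only a limit of the assay, > 50000 nM.
Compound 3, `Oc1ccccc1-c1cc(-c2ccccn2)cc(-c2ccccc2O)n1`, in this assay reaches only a limit of the assay, > 50000 nM.

Compound 3 therefore stands at a limit and not at a number, and the two other measured compounds stand at the same limit, as the limit of > 50000 nM in this assay, at which 3 of the 3 values shown sit, records. The steps between the measured compounds cannot be read: a step that the two limits leave unreadable from compound 1 to compound 2, a step that the two limits leave unreadable from compound 1 to compound 3 and a step that the two limits leave unreadable from compound 2 to compound 3 all lie between values that are limits. Compound 4, `Oc1ccccc1-c1cc(-c2cccnc2)cc(-c2ccccc2O)n1`, is not yet measured in this assay. It differs from compound 3 in one place: pyridin-3-yl in place of pyridin-2-yl on an aromatic carbon. For the measured compounds named here, no measured step bears on this change with a readable size, so the expectation rests only on the three compounds sitting at the limit. The step from compound 3 to compound 4 is expected to be a number no higher from compound 3 to compound 4 (the limit leaves the size open), most likely again unreadable against the limit. Compound 4 is estimated in this assay at 50000 nM, within a range from 20000 nM to 100000 nM.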

Compound 4, half-maximal inhibitory concentration: > 50000 nM
Compound 4: a limit, no number (the forecaster's own chance of this, stated with the estimate: 85%); the middle value lies on the limit itself.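

In this assay compound 4 gives > 50000 nM as a limit of the assay and not a number. Its steps from compound 1, compound 2 and compound 3 therefore cannot be read, and all four compounds share one limit: the limit of > 50000 nM in this assay, at which 4 of the 4 values shown sit.
The compounds shown leave open whether thiophen-3-yl, furan-3-yl, pyridin-2-yl and pyridin-3-yl differ at all in this read-out.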